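Fluorophenyl in Place of Chlorophenyl on a Carbamate Oxygen

The compounds below may be only part of what the source reports. "The series", "measured", "known", "first", "only" and "open" are said of these compounds alone.

Compound 1 `CCCCCCCOc1ccc(NC(=O)Oc2ccccc2F)cc1`: 28 nM
Compound 2 `CCCCOc1ccc(CNC(=O)Oc2cccc(C(F)(F)F)c2)cc1`: 40 nM
Compound 3 `CCCCOc1ccc(CNC(=O)Oc2cccc(Cl)c2)cc1`: 12 nM

Three aryl carbamates were measured in an assay on H4 cells for inhibition of Fatty-acid amide hydrolase 1 (Homo sapiens); a higher number here means a weaker inhibitor, a lower number a stronger inhibitor. Compound 3 gives the lowest number of the three in this assay, with compound 1 at 28 nM and compound 2 at 40 nM both standing above it.

Compound 4 `CCCCOc1ccc(CNC(=O)Oc2ccc(F)cc2)cc1` has not yet been measured. It differs from compound 3 in one place: 4-fluorophenyl in place of 3-chlorophenyl on an oxygen next to a carbonyl group.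

For the measured compounds named here, only one measured step concerns the aryl group on this oxygen. In this assay the step of a 3.3-fold lower number from compound 2 to compound 3 (0.52 log units; beyond the scatter) shows that changing this aryl group can move the number beyond the scatter. Compound 1 also carries a fluorophenyl on the carbamate oxygen, though with a different core, and it gives 28 nM in this assay, above compound 3. Because compound 3 gives 12 nM and compound 1 gives 28 nM, compound 4 is expected to lie above compound 3, by a modest step of a 2.9-fold higher number from compound 3 to compound 4 (0.46 log units; beyond the scatter).

The estimate for compound 4 in this assay is 35 nM, with a range from 12 nM to 100 nM.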

Compound 4, half-maximal inhibitory concentration: 4.6 nM
The estimate for compound 4 lay 7.6-fold (0.88 log units) above the measured number, outside the stated range (below it).
By their numbers in this assay, from the lowest: compound 4; then compound 3; then compounds 1 and 2 (each within the scatter of the next).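

Replacing 3-chlorophenyl with 4-fluorophenyl on the oxygen next to a carbonyl group gives a 2.6-fold lower number from compound 3 to compound 4 (0.42 log units; beyond the scatter) in this assay and shows that this position can still yield a lower number after the earlier change. Together with a 3.3-fold lower number from compound 2 to compound 3 (0.52 log units; beyond the scatter) on the same core, it makes two steps at this position that lower the number beyond the scatter, and the second occurs even though the heavy-atom count stays the same and neither group has hydrogen-bond donors or acceptors. Nothing available explains why this exchange lowers the number.

This single step changes both the halogen and its place on the ring, so the compounds shown do not separate the two contributions, and 4-chlorophenyl or 3-fluorophenyl on the same oxygen with the same core would be needed to tell them apart. Also open, from the compounds shown here alone, is where an unsubstituted phenyl or a 4-methoxyphenyl at this position would stand relative to the halogenated groups, and whether the gain from 4-fluorophenyl would persist with a longer chain on the shared core.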